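The compounds below may be only part of what the source reports. "The series", "measured", "known", "first", "only" and "open" are said of these compounds alone.

Measured compounds:
compound 1, `CCCCCCCCS(=O)(=O)Nc1cc(-c2cccc(Cl)c2)ccc1C(=O)O`: 13800 nM
compound 2, `CCCCCCCCS(=O)(=O)Nc1cc(-c2ccc(Cl)cc2)ccc1C(=O)O`: 18100 nM
compound 3, `CCCCCCCCS(=O)(=O)Nc1ccc(-c2cccc(Cl)c2)cc1C(=O)O`: 8900 nM

In an assay on mitochondria (strain BALB/c) for inhibition of glycerol-3-phosphate acyltransferase 1, mitochondrial (Mus musculus), read by scintillation counting, with a stated time of 10 min (a higher number here means a weaker inhibitor, a lower number a stronger inhibitor), compound 1 gives 13800 nM. Compound 2 differs from compound 1 by 4-chlorophenyl in place of 3-chlorophenyl on an aromatic carbon, and this change made a 1.3-fold higher number from compound 1 to compound 2 (0.12 log units; within the scatter), so the two values are not distinguished by this assay. Compound 3 gives 8900 nM in this assay; how its core differs from that of compound 1 is not broken down here. Its number is within the scatter of that of compound 1 and beyond the scatter of that of compound 2.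

Compound 4, `CCCCCCCCS(=O)(=O)Nc1ccc(-c2ccc(Cl)cc2)cc1C(=O)O`, has not yet been measured. It differs from compound 3 by 4-chlorophenyl in place of 3-chlorophenyl on an aromatic carbon. This is the same kind of change as that from compound 1 to compound 2, not the same change, since the place is meta to a carboxy group and para to a large group in compound 3, whereas in compound 1 it is meta to a large group and para to a carboxy group. For this assay a step of a 1.3-fold higher number from compound 3 to compound 4 (0.11 log units; within the scatter) is expected, because the same kind of change made a 1.3-fold higher number from compound 1 to compound 2 (0.12 log units; within the scatter). Compound 4 is therefore estimated at 11500 nM, expected to lie between 5000 nM and 26000 nM.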

Compound 4, half-maximal inhibitory concentration: 9200 nM
Compound 4: middle estimate off by 1.3-fold (0.10 log units), on the high side; the range from low to high includes it.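

In this assay, 4-chlorophenyl in place of 3-chlorophenyl gave a 1.0-fold higher number from compound 3 to compound 4 (0.01 log units; within the scatter), so the two groups are not told apart on the core of compound 3. Set beside the earlier step, the change carries from one core to the other with no difference that this measurement can resolve: the same change on two cores in this assay, a 1.3-fold higher number (0.12 log units; within the scatter) from compound 1 to compound 2 and a 1.0-fold higher number (0.01 log units; within the scatter) from compound 3 to compound 4, 1.3-fold (0.10 log units) apart, within the scatter of two such steps This shows only that the change stays small on these two cores; as neither step lies beyond the scatter, it does not show that a larger effect would carry across, and two pairs give no rule for other cores or other changes.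

The compounds shown leave open whether a methoxy or trifluoromethyl group in place of the chlorine, or a longer chain in place of the octyl chain, would move the number in this assay beyond the scatter. They also leave open whether the two chlorophenyl groups would still match with an amide in place of the carboxy group.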